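Chloro added to the anilide of compound 3

The source may hold more compounds than are shown below. What is called first, only, known or untested is meant among the compounds shown, and "the series" means these compounds.

The series shares one core; compound 1 is `Cn1cc(SCC(=O)Nc2ccccc2Cl)c2ccccc21`, compound 2 is `Cn1cc(SCC(=O)Nc2ccc(Cl)c(Cl)c2)c2ccccc21` and compound 3 is `Cn1cc(SCC(=O)Nc2cccc(Cl)c2)c2ccccc21`. In an ADME assay on HEK-293T cells (Homo sapiens) for cytotoxicity, read by CCK-8 assay, with a stated time of 48 h (a lower number here means that less compound is tolerated, a higher number that more compound is tolerated), compound 3 gives > 100000 nM, a limit of the assay rather than a number. Compound 1 likewise reaches only the limit > 100000 nM in this assay. Compound 2 also sits at the limit > 100000 nM in this assay. Among the compounds with values here, the steps a step that the two limits leave unreadable from compound 1 to compound 3 and a step that the two limits leave unreadable from compound 2 to compound 3 are thus unreadable in size, and the limit of > 100000 nM in this assay, at which 3 of the 3 values shown sit, is the only evidence in hand. Compound 4 is `Cn1cc(SCC(=O)Nc2cc(Cl)ccc2Cl)c2ccccc21`; it differs from compound 3 by chloro in place of hydrogen on an aromatic carbon. With both measured steps unreadable, the step of a number no higher from compound 3 to compound 4 (the limit leaves the size open) is expected to stay within the scatter. Compound 4 is expected at 100000 nM, within 40000 nM to 250000 nM, most likely again reported only as a limit.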

Compound 4, half-maximal cytotoxic concentration: > 100000 nM
Compound 4 gave a limit, no number; the forecaster's own chance of this, stated with the estimate: 85%; the middle value sits exactly at the limit.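

No step to compound 4 can be read, from compound 3 or from compound 1, since both ends of each are limits in this assay: the limit of > 100000 nM in this assay, at which 4 of the 4 values shown sit.

The compounds shown leave open whether any chloro placement on the anilide changes cytotoxicity in this assay.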